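Swapping 3-chlorobenzyl for 4-methoxybenzyl: working notes

The compounds below may be only part of what the source reports. "The series", "measured", "known", "first", "only" and "open" are said of these compounds alone.

In a functional assay on a cell-free system (plasma, Oryctolagus cuniculus) for inhibition, with stated times of 5 min, 1 min and 6 min (a higher number here means a weaker inhibitor, a lower number a stronger inhibitor), compound 1 `CCOC(=O)c1c(C)nc(-c2cccc(C#N)c2)n1OC` gives 9130 nM and compound 2 `CCOC(=O)c1c(C)nc(-c2cccc(C#N)c2)n1OC(C)C` gives 6740 nM, with a 1.4-fold lower number from compound 1 to compound 2 (0.13 log units; within the scatter). Compound 3 `CCOC(=O)c1c(C)nc(-c2cccc(C#N)c2)n1OCc1cccc(Cl)c1` stands highest of the three at 19400 nM. Among the compounds with values here, the steps that bear on it are a 2.1-fold higher number from compound 1 to compound 3 (0.33 log units; beyond the scatter) and a 2.9-fold higher number from compound 2 to compound 3 (0.46 log units; beyond the scatter), both modest. Compound 4 `CCOC(=O)c1c(C)nc(-c2cccc(C#N)c2)n1OCc1ccc(OC)cc1` has 4-methoxyphenyl in place of 3-chlorophenyl on a saturated chain carbon bound to an oxygen on an aromatic ring. Within the data shown here, no measured step tests a substituent change on this phenyl group, so the modest steps above set the only available scale. The expected change, none beyond the scatter, is a 1.2-fold lower number from compound 3 to compound 4 (0.08 log units; within the scatter). For compound 4 the estimated value is 16000 nM, with an expected range of 7000 nM to 35000 nM.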

Compound 4, half-maximal inhibitory concentration: 6830 nM
Compound 4: the middle estimate sits 2.3-fold (0.37 log units) above what was measured; the whole stated range lies above it.
By their numbers in this assay, from the lowest: compounds 2, 4 and 1 (each within the scatter of the next); then compound 3.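

In this assay the benzyl group on this oxygen is sensitive to its ring substituent: 4-methoxyphenyl in place of 3-chlorophenyl gives a step beyond the scatter (a 2.8-fold lower number from compound 3 to compound 4 (0.45 log units; beyond the scatter)). The higher number of compound 3 therefore does not extend to every benzyl group here, since the steps from the smaller groups stay within the scatter (a 1.0-fold higher number from compound 2 to compound 4 (0.01 log units; within the scatter); a 1.3-fold lower number from compound 1 to compound 4 (0.13 log units; within the scatter)). Nothing available explains the difference between the two benzyl groups.

This change swaps the substituent and shifts its ring position together, so the two contributions remain inseparable. How an unsubstituted benzyl group, or an amine on the phenyl ring, would read is open.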